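Methyl to bromo on the pyridin-4-yl compound

The compounds below may be only part of what the source reports. "The series", "measured", "known", "first", "only" and "open" are said of these compounds alone.

Compound 1 `Cc1ccc(S(=O)(=O)N2C/C(=C\c3cccnc3)C(=O)/C(=C/c3ccccc3F)C2)cc1`: 4200 nM
Compound 2 `O=C1/C(=C/c2cccnc2)CN(S(=O)(=O)c2ccc(C(F)(F)F)cc2)C/C1=C\c1ccccc1F`: 2400 nM
Compound 3 `Cc1ccc(S(=O)(=O)N2C/C(=C\c3ccncc3)C(=O)/C(=C/c3ccccc3F)C2)cc1`: 9700 nM
Compound 4 `O=C1/C(=C/c2ccncc2)CN(S(=O)(=O)c2ccc(Br)cc2)C/C1=C\c1ccccc1F`: not yet measured

All of these values come from a functional assay on HepG2 cells (Homo sapiens) for cytotoxicity, read by MTT assay, with a stated time of 24 h; on this read-out lower numbers stand for stronger inhibition and higher numbers for weaker inhibition. Compound 3 gives the highest of the three numbers at 9700 nM, and the gap to its nearest neighbour is a 2.3-fold higher number from compound 1 to compound 3 (0.36 log units; beyond the scatter). Compound 4 differs from compound 3 in one place, with bromo in place of methyl on an aromatic carbon, para to a large group: bromo in place of methyl on an aromatic carbon. Going by the values given here, no bromo compound has been measured yet. The closest evidence is a 1.8-fold lower number from compound 1 to compound 2 (0.24 log units; within the scatter), where trifluoromethyl takes the place of methyl on the same aromatic carbon, though with pyridin-3-yl rather than pyridin-4-yl elsewhere in the molecule. The other measured step, a 2.3-fold higher number from compound 1 to compound 3 (0.36 log units; beyond the scatter), concerns the pyridine and says nothing direct about this position. Only a small move toward a lower number is therefore expected in this assay, with the expected step being a 1.6-fold lower number from compound 3 to compound 4 (0.21 log units; within the scatter). For compound 4 the estimated value is 6000 nM, with an expected range of 2500 nM to 13000 nM.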

Compound 4, half-maximal inhibitory concentration: 9300 nM
Compound 4: the middle estimate sits 1.6-fold (0.19 log units) below what was measured, and the stated range covers the measured number.
By their numbers in this assay, from the lowest: compounds 2 and 1 (each within the scatter of the next); then compounds 4 and 3 (each within the scatter of the next).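

In this assay the change of methyl to bromo, on an aromatic carbon para to a large group, gives a 1.0-fold lower number from compound 3 to compound 4 (0.02 log units; within the scatter) and so leaves the number in the scatter with pyridin-4-yl in the molecule. The earlier trifluoromethyl step, a 1.8-fold lower number from compound 1 to compound 2 (0.24 log units; within the scatter), also stayed within the scatter, but with pyridin-3-yl, so the 4-methylphenyl group has now been exchanged in both pyridine settings without a change beyond the scatter. Nothing available on these compounds accounts for this result.

The compounds shown leave open whether an amine or a carboxylic acid on this same aromatic carbon would move the number beyond the scatter. They also leave open whether bromo gives the same result with pyridin-3-yl in the molecule.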